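The source may hold more compounds than are shown below. What is called first, only, known or untested is meant among the compounds shown, and "the series" means these compounds.

In an assay on CHO cells for agonist activity at 5-hydroxytryptamine receptor 1D (Homo sapiens), read by GTPgammaS binding (on this read-out higher numbers stand for an effect only at larger amounts of compound and lower numbers for an effect already at smaller amounts), compound 1 `O[C@@H]1Cc2ccccc2[C@H]1NC1CCN(CCCc2c[nH]c3ccc(-n4cnnc4)cc23)CC1` gives 13 nM and compound 2 `CN(Cc1ccsc1)C1CCN(CCCc2c[nH]c3ccc(-n4cnnc4)cc23)CC1` gives 4.2 nM. Of these two numbers, compound 2 holds the lower one; the step of a 3.1-fold lower number from compound 1 to compound 2 (0.49 log units; beyond the scatter) accompanied methyl((thiophen-3-yl)methyl)amino in place of (2-hydroxy-2,3-dihydro-1H-inden-1-yl)amino on a saturated ring carbon. Compound 3 `C[C@H](NC1CCN(CCCc2c[nH]c3ccc(-n4cnnc4)cc23)CC1)c1ccccc1` differs from compound 2 at that same place: (1-phenylethyl)amino in place of methyl((thiophen-3-yl)methyl)amino on a saturated ring carbon. For the measured compounds named here, the only measured step that bears on this change is the one between compound 1 and compound 2, which was modest and concerned the same ring carbon. Because a 3.1-fold lower number from compound 1 to compound 2 (0.49 log units; beyond the scatter) accompanied the entry of the very group that compound 3 now loses again, a return toward a somewhat higher number is expected for compound 3, of the size a 1.9-fold higher number from compound 2 to compound 3 (0.28 log units; within the scatter). Compound 3 is therefore estimated at 8 nM in this assay, with an expected range from 3 nM to 25 nM.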

Compound 3, half-maximal effective concentration: 12 nM
Estimate against measurement, compound 3: 1.5-fold (0.18 log units) below, within the range that was stated.
By their numbers in this assay, from the lowest: compound 2; then compounds 3 and 1 (each within the scatter of the next).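

In this assay, (1-phenylethyl)amino in place of methyl((thiophen-3-yl)methyl)amino on the saturated ring carbon gave a 2.9-fold higher number from compound 2 to compound 3 (0.46 log units; beyond the scatter) and so left the lower number with compound 2, showing that the number at this position does not depend only on the indane-type group of compound 1 being absent. Replacing 2-hydroxy-2,3-dihydro-1H-inden-1-yl with 1-phenylethyl on the amine nitrogen gave a 1.1-fold lower number from compound 1 to compound 3 (0.03 log units; within the scatter), so these two groups do not separate in this assay, although one carries a hydroxyl and the other does not. Nothing measured here accounts for either step.

Compound 2 differs from the other two both by the methyl on the amine nitrogen and by its thiophene ring, and these compounds do not tell the two apart. A methyl on the nitrogen of the (1-phenylethyl)amino group, or a benzyl in place of the thiophen-3-ylmethyl, would bear on this.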